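A few compounds are considered here, and "the series" means these few. Any claim that something is new, unique, unknown or untested is made for them only; others in the source may bear on it.

Compound 1 `O=C(N[C@@H]1CCNC1)c1cc(-c2ccc(NS(=O)(=O)c3cccc(Cl)c3Cl)cc2)nc2[nH]ncc12` — in an assay for inhibition of serine/threonine-protein kinase Sgk1 (Homo sapiens), with stated times of 30 min and 60 min, in the presence of a further agent that is not named here (on this read-out higher numbers stand for weaker inhibition and lower numbers for stronger inhibition), compound 1 gives only a limit, < 1 nM.
Compound 2 `CC(C)NC(=O)c1cc(-c2ccc(NS(=O)(=O)c3cccc(Cl)c3Cl)cc2)nc2[nH]ncc12` — in this assay compound 2 gives 68 nM.

Compound 1 stands at the strong end of what is shown, but its value is a limit and not a number, as the limit of < 1 nM in this assay, at which 1 of the 2 values shown sits, records. Going by the values given here, the only measured step on this core is an at least 68-fold higher number from compound 1 to compound 2 (1.83 log units; beyond the scatter), where an isopropyl stands in place of the pyrrolidin-3-yl on the amide-type nitrogen; that step is large and lies beyond the scatter.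

Compound 3 `CCN1CCC(CNC(=O)c2cc(-c3ccc(NS(=O)(=O)c4cccc(Cl)c4Cl)cc3)nc3[nH]ncc23)C1` is not yet measured. It differs from compound 1 by (1-ethylpyrrolidin-3-yl)methyl in place of pyrrolidin-3-yl on an amide-type nitrogen. The five-membered ring with its nitrogen is kept, but the hydrogen-bond donor of that ring is gone, a methylene is inserted, and an ethyl sits on the ring nitrogen. The step from compound 1 to compound 2 shows that replacing pyrrolidin-3-yl by a group without a ring nitrogen costs a great deal; compound 3 keeps the ring nitrogen, so a smaller loss is expected. The step from compound 1 to compound 3 is therefore estimated as an at least 8.0-fold higher number from compound 1 to compound 3 (0.90 log units; beyond the scatter), toward weaker inhibition. For compound 3 the expected value is 8 nM, in a range from 1.5 nM to 60 nM.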

Compound 3, half-maximal inhibitory concentration: < 1 nM
Compound 3: only a limit was reported; the forecaster's own chance of this, stated with the estimate: 15%; middle value at least 8.0-fold (0.90 log units) from the limit.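

With (1-ethylpyrrolidin-3-yl)methyl on the amide-type nitrogen, compound 3 gives < 1 nM in this assay, and this value is a limit of the assay, not a number. Set against the isopropyl group, this larger group gives a large change, an at least 68-fold lower number from compound 2 to compound 3 (1.83 log units; beyond the scatter), so the strong end of the assay is reached by a second group carrying a five-membered ring with its nitrogen. Strong inhibition at this place therefore does not depend on the hydrogen-bond donor of pyrrolidin-3-yl, nor is it lost with the added methylene and ethyl, as the entering group has no such donor and compound 3 still sits at the same limit as compound 1: the limit of < 1 nM in this assay, at which 2 of the 3 values shown sit.

From the compounds shown here alone, the step from compound 1 to compound 3 cannot be read, so any order between the two stays open, and the true size of the effect of the change remains hidden behind the limit. The compounds shown also leave open whether the ring nitrogen itself is what separates these groups from isopropyl, a question that a cyclopentyl group on the amide-type nitrogen would address.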